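A few compounds are considered here, and "the series" means these few. Any claim that something is new, unique, unknown or untested is made for them only; others in the source may bear on it.

Measured so far:
compound 1 `COc1n[nH]c2ncc(-c3cn(-c4c(F)ccc(NS(=O)(=O)c5cccc(C#N)c5)c4F)nn3)cc12`, 3.3 nM
compound 2 `COc1cccc(S(=O)(=O)Nc2ccc(F)c(-n3cc(-c4cnc5[nH]nc(OC)c5c4)nn3)c2F)c1`, 2.3 nM
compound 3 `COc1n[nH]c2ncc(-c3cn(-c4c(F)ccc(NS(=O)(=O)c5cccc(C)c5)c4F)nn3)cc12`, 4.4 nM

All three were tested in an assay on Sf9 cells for inhibition of mitogen-activated protein kinase kinase kinase 20 (Homo sapiens), read by ADP-Glo, with a stated time of 30 min; a lower number here means a stronger inhibitor, a higher number a weaker inhibitor. They share one core and differ only in the group carried on the sulfonamide-bearing ring: a nitrile in compound 1, a methoxy in compound 2, a methyl in compound 3. On the numbers shown, compound 3 gives the largest of the three values, yet a 1.3-fold higher number from compound 1 to compound 3 (0.12 log units; within the scatter) and a 1.9-fold higher number from compound 2 to compound 3 (0.28 log units; within the scatter) both fall within the scatter, so the three compounds cannot be told apart. The remaining comparison, a 1.4-fold lower number from compound 1 to compound 2 (0.16 log units; within the scatter), is also within the scatter.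

Compound 4 `COc1n[nH]c2ncc(-c3cn(-c4c(F)ccc(NS(=O)(=O)c5cccc(C(C)C)c5)c4F)nn3)cc12` has not yet been measured. It differs from compound 3 by isopropyl in place of methyl on an aromatic carbon. The closest precedents are the three steps above, in which small groups of different kinds were exchanged at this same ring carbon without any change beyond the scatter. Nothing measured here speaks for or against a larger alkyl group at that position, so the expectation for this assay is a step of a 1.1-fold higher number from compound 3 to compound 4 (0.06 log units; within the scatter) from compound 3 to compound 4, that is, no change beyond the scatter. Compound 4 is therefore expected to give about 5 nM, with a range from 2 nM to 13 nM.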

Compound 4, half-maximal inhibitory concentration: 6.9 nM
For compound 4 the middle estimate is 1.4-fold (0.14 log units) below the measured one, and the stated range covers the measured number.
By their numbers in this assay, from the lowest: compounds 2, 1, 3 and 4 (each within the scatter of the next, the first and the last beyond it).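

In this assay this aromatic carbon accepts an isopropyl group as well as a methyl group, since a 1.6-fold higher number from compound 3 to compound 4 (0.20 log units; within the scatter) is a step that stays inside the scatter, so this exchange alone cannot separate the two compounds. The wider comparison does add something new. The earlier compounds shown here could not be told apart, whereas compound 4 gives the first differences beyond the scatter at this position: a 3.0-fold higher number from compound 2 to compound 4 (0.48 log units; beyond the scatter) and a 2.1-fold higher number from compound 1 to compound 4 (0.32 log units; beyond the scatter) are both modest steps, but they show that the group at this carbon can shift the number measurably, with isopropyl on the higher side of methoxy and nitrile. The compounds shown offer no measurement that would explain these differences.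

From the compounds shown here alone, it remains open whether the upward drift would continue with another alkyl group such as tert-butyl or cyclohexyl, or with a longer chain such as n-butyl, and whether such a step would grow beyond modest. The results also say nothing about how an amine, a carboxylic acid or a phenyl ring at this same carbon would read in this assay.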